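The compounds below may be only part of what the source reports. "The series", "measured", "known", "first", "only" and "open" are said of these compounds alone.

In a functional assay on MCF7 cells (Homo sapiens) for cytotoxicity, read by CellTiter-Glo, with a stated time of 5 days (on this read-out lower numbers stand for stronger inhibition and higher numbers for weaker inhibition), compound 1 (`CC/C(=C(/c1ccc(/C=C/C(=O)O)cc1)c1ccc2[nH]c(=O)sc2c1)c1ccccc1`) gives 158 nM and compound 2 (`CC/C(=C(/c1ccc(/C=C/C(=O)O)cc1)c1ccc2[nH]ncc2c1)c1ccccc1Cl`) gives 2 nM as the lower of the two numbers, a gap beyond the usual scatter. Compound 3 (`CC/C(=C(/c1ccc(/C=C/C(=O)O)cc1)c1ccc2[nH]ncc2c1)c1ccccc1C#N`) differs from compound 2 by cyano in place of chloro on an aromatic carbon ortho to a large group. Among the compounds with values here, no measured pair shows this change, so only a modest rise in the number is expected in this assay here. The estimated 2.5-fold higher number from compound 2 to compound 3 (0.40 log units; beyond the scatter) would be a small weakening. Compound 3 is expected at 5 nM with an estimated range from 1.5 nM to 20 nM in all.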

Compound 3, half-maximal inhibitory concentration: 12 nM
Compound 3: middle estimate off by 2.4-fold (0.38 log units), on the low side; the measured number falls inside the stated range.
By their numbers in this assay, from the lowest: compound 2; then compound 3; then compound 1.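

Within the data shown here, the step of a 6.0-fold higher number from compound 2 to compound 3 (0.78 log units; beyond the scatter) in this assay gives the first measured reading of cyano in place of chloro on this aromatic carbon, ortho to a large group. The 2-chlorophenyl to 2-cyanophenyl change weakens inhibition modestly, by more than the usual scatter, and one added heavy atom and one hydrogen-bond acceptor come with it. Nothing on hand accounts for this step. The compounds shown leave open how an amine or a methoxy group on this same carbon would compare, and whether this step holds on another core.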